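Swapping isopropyl for chloro on a weakly cytotoxic core

The source may report more compounds than this note shows. Statements on the series, on what has been measured and on what is new or still open speak of the compounds shown alone.

Of the compounds shown here, two sharing one core have been tested in a functional assay on RD cells (Homo sapiens) for inhibition, read by luminescence and ATP content, with a stated time of 72 h; on this read-out lower numbers stand for higher toxicity in this test and higher numbers for lower toxicity in this test. Compound 1 `Nc1ccc(-c2ccc3ncc(-c4noc(C(F)(F)F)n4)cc3c2)cn1` carries a 6-aminopyridin-3-yl group. In this assay compound 1 reaches only a limit of > 2500 nM. Compound 2 `CC(C)c1ccc(-c2ccc3ncc(-c4noc(C(F)(F)F)n4)cc3c2)cc1` carries 4-isopropylphenyl in its place. In this assay compound 2 likewise reaches only a limit of > 200000 nM. The step that the two limits leave unreadable from compound 1 to compound 2 therefore cannot be read, since both ends sit at limits (the limit of > 200000 nM in this assay, at which 1 of the 2 values shown sits, and (the limit of > 2500 nM in this assay, at which 1 of the 2 values shown sits)). Compound 3 `FC(F)(F)c1nc(-c2cnc3ccc(-c4ccc(Cl)cc4)cc3c2)no1` differs from compound 2 by chloro in place of isopropyl on an aromatic carbon. No measured step concerns this exchange, and the single step shown, from compound 1 to compound 2, is itself unreadable, so it offers no direction. The step of an at least 1.3-fold lower number from compound 2 to compound 3 (0.12 log units; that floor lies within the scatter) is expected to stay within the usual scatter, most likely ending at a limit again. For compound 3 the estimate in this assay is 150000 nM, with a range from 20000 nM to 300000 nM.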

Compound 3, half-maximal cytotoxic concentration: > 200000 nM
Compound 3 was reported as a limit; the forecaster's own chance of this, stated with the estimate: 70%; at least 1.3-fold (0.12 log units) between middle value and limit.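

In this assay compound 3 gives > 200000 nM, again a limit, so neither its step from compound 1 nor its step from compound 2 can be read: the limit of > 200000 nM in this assay, at which 2 of the 3 values shown sit.

The compounds shown leave open how far compound 1, compound 2 and compound 3 truly differ in toxicity in this test.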